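Saturated ring to aromatic ring on the ester carbonyl

The source may report more compounds than this note shows. Statements on the series, on what has been measured and on what is new or still open speak of the compounds shown alone.

Three compounds share one core and differ in the group on the oxygen on a saturated carbon. Compound 1 `CC(C)=CC[C@@H](OC[C@H](C)O)C1=CC(=O)c2c(O)ccc(O)c2C1=O` gives 40300 nM in a functional assay on HeLa cells (Homo sapiens) for cytotoxicity, read by MTT assay; on this read-out lower numbers stand for stronger inhibition and higher numbers for weaker inhibition. Compound 2 `CCC(CO[C@H](CC=C(C)C)C1=CC(=O)c2c(O)ccc(O)c2C1=O)OC(C)=O` gives 44000 nM, and the change a 1.1-fold higher number from compound 1 to compound 2 (0.04 log units; within the scatter). Compound 3 `CC(C)=CC[C@@H](OC(=O)C1CCCO1)C1=CC(=O)c2c(O)ccc(O)c2C1=O` gives 17000 nM and stands lowest of the three; the move a 2.4-fold lower number from compound 1 to compound 3 (0.37 log units; beyond the scatter) and the move a 2.6-fold lower number from compound 2 to compound 3 (0.41 log units; beyond the scatter), both modest but beyond the scatter.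

Compound 4 `CC(C)=CC[C@@H](OC(=O)c1ccoc1)C1=CC(=O)c2c(O)ccc(O)c2C1=O` is not yet measured. It differs from compound 3 in one place: furan-3-yl in place of oxolan-2-yl on a carbonyl carbon. For the measured compounds named here, no measured step touches this place; the two measured steps that gave lower numbers swapped a chain-bearing group for the (oxolan-2-yl)carbonyl, and they show only that the ester-type group of compound 3 is favourable next to the chain-bearing groups of compound 1 and compound 2. Whether the ring within that ester matters is not shown. The expectation is therefore a step of a 1.1-fold lower number from compound 3 to compound 4 (0.03 log units; within the scatter), within the scatter, with no direction claimed. Compound 4 is estimated at 16000 nM, with a range from 6000 nM to 42000 nM.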

Compound 4, half-maximal inhibitory concentration: > 100000 nM
Compound 4 gave a limit, no number; the forecaster's own chance of this, stated with the estimate: 5%; middle value at least 6.2-fold (0.79 log units) from the limit.
By their numbers in this assay, from the lowest: compound 3; then compounds 1 and 2 (each within the scatter of the next). At a limit, above all of these: compound 4.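

In this assay, for the compounds shown here, the ring within the ester proves to matter, which the earlier compounds could not show: with the ester kept in place, furan-3-yl in place of oxolan-2-yl on the carbonyl carbon gives an at least 5.8-fold higher number from compound 3 to compound 4 (0.76 log units; beyond the scatter). The result for compound 4 is a limit of the assay and not a number: the limit of > 100000 nM in this assay, at which 1 of the 4 values shown sits.

An ester-type group alone therefore does not secure a lower number, as (furan-3-yl)carbonyl compares unfavourably even with the chain-bearing groups, giving an at least 2.4-fold higher number from compound 1 to compound 4 (0.39 log units; beyond the scatter) and an at least 2.2-fold higher number from compound 2 to compound 4 (0.35 log units; beyond the scatter).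

The compounds shown do not separate the change from a non-aromatic to an aromatic ring from the change in where the ring is joined to the carbonyl carbon, as oxolan-2-yl and furan-3-yl differ in both; furan-2-yl and oxolan-3-yl would pull these two apart. As far as these compounds go, it also remains open whether the ring oxygen is needed at all, which a cyclopentyl or phenyl group on the same carbonyl carbon would address, and how far the number for compound 4 lies past its limit.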